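The compounds below may be only part of what the source reports. "The series", "measured", "known", "first", "only" and "open" are said of these compounds alone.

Within the data shown here, compound 2 `CC(Oc1ccccc1C=O)C1=NCCN1` gives 8710 nM in an assay on CHO cells for displacement of a labelled ligand from Alpha-2C adrenergic receptor (Homo sapiens) (a higher number here means a weaker inhibitor, a lower number a stronger inhibitor), and holds the highest of the two numbers measured so far. Among the measured compounds shown here, the nearest is compound 1 `COc1ccccc1OC(C)C1=NCCN1`, which in this assay gives 832 nM; the step of a 10-fold higher number from compound 1 to compound 2 (1.02 log units; beyond the scatter), formyl in place of methoxy on an aromatic carbon, is the only measured step. Compound 3 `CC(=O)c1ccccc1OC(C)C1=NCCN1` is still to be measured. The change from compound 2 to compound 3 is methyl in place of hydrogen on a carbonyl carbon, read one bond further out as formyl to acetyl. For the measured compounds named here, no measured step touches the carbonyl carbon itself; the single measured step concerns an exchange of the whole group on the aromatic carbon and does not speak to a change within the formyl. For compound 3 a step of a 1.2-fold lower number from compound 2 to compound 3 (0.09 log units; within the scatter) within the scatter is therefore expected. Compound 3 is estimated at 7000 nM, with a range from 2500 nM to 20000 nM.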

Compound 3, inhibition constant: 7410 nM
Compound 3: the middle estimate sits 1.1-fold (0.02 log units) below what was measured, and the stated range covers the measured number.
By their numbers in this assay, from the lowest: compound 1; then compounds 3 and 2 (each within the scatter of the next).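

In this assay, methyl in place of hydrogen on the carbonyl carbon gives a 1.2-fold lower number from compound 2 to compound 3 (0.07 log units; within the scatter) and so does not separate formyl from acetyl. Acetyl in place of methoxy on the aromatic carbon gives an 8.9-fold higher number from compound 1 to compound 3 (0.95 log units; beyond the scatter), and formyl in the same place gives a 10-fold higher number from compound 1 to compound 2 (1.02 log units; beyond the scatter), so among these compounds the weaker binding relative to compound 1 does not depend on the hydrogen of the formyl. Nothing at hand explains the gap between methoxy and these two carbonyl groups.

From the compounds shown here alone, whether a longer chain on the carbonyl carbon, as in propanoyl, would stay at the level of compound 2 and compound 3 remains open. Also open, going by these compounds, is how an amide or a carboxylic acid on the aromatic carbon would compare with methoxy, formyl and acetyl.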